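The source may hold more compounds than are shown below. What is called first, only, known or untested is meant among the compounds shown, and "the series" means these compounds.

Measured so far in a physicochemical assay for lipophilicity, measured as octanol-water partition, at pH 7.4; a higher number here means a more lipophilic compound, a lower number a more polar compound:
- compound 1 `O=C([C@H](O)CS(=O)(=O)c1ccc2cc(Cl)ccc2c1)N1CCC(N2CCNC2=O)CC1`: 1.73
- compound 2 `O=C([C@H](O)CS(=O)(=O)c1ccc2cc(Cl)ccc2c1)N1CCC(N2CCCC2)CC1`: 1.56

Compound 2 lies within the scatter of compound 1, and the two cannot be ranked. Next comes compound 3 `O=C([C@H](O)CS(=O)(=O)c1ccc2cc(Cl)ccc2c1)N1CCC(N2CCCCCC2=O)CC1`, with 2-oxoazepan-1-yl in place of pyrrolidin-1-yl on a saturated ring carbon. Among the measured compounds shown here, the only measured step at this place is a number 0.17 log units lower from compound 1 to compound 2 (within the scatter), which stays within the scatter. For the measured compounds named here, it is a weak guide, and no seven-membered ring has yet been measured here. The entering group is clearly larger than the pyrrolidin-1-yl it replaces, and an upward step in this assay beyond the scatter is expected, with wide uncertainty. The expected step is a number 0.84 log units higher from compound 2 to compound 3 (beyond the scatter). For compound 3 the estimated value is 2.4, within an expected range of 1.9 to 2.9.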

Compound 3, distribution coefficient: 2.52
Beside the measured number, compound 3's estimate is 0.12 log units below it, within the range that was stated.
By their numbers in this assay, from the lowest: compounds 2 and 1 (each within the scatter of the next); then compound 3.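

On the saturated ring carbon, the earlier pair of 2-oxoimidazolidin-1-yl and pyrrolidin-1-yl could not be ranked in this assay, but this position now gives readable steps beyond the scatter: a number 0.96 log units higher from compound 2 to compound 3 (beyond the scatter) and a number 0.79 log units higher from compound 1 to compound 3 (beyond the scatter). The 2-oxoazepan-1-yl group is thus the first at this place to separate from both earlier groups, and compound 3 stands apart from compound 1 and compound 2. Nothing measured here explains the size of either step.

The change from pyrrolidin-1-yl to 2-oxoazepan-1-yl brings in the seven-membered ring and the carbonyl together, and the compounds shown cannot assign the step to either one. Among the compounds shown here, open too is where azepan-1-yl or 2-oxopyrrolidin-1-yl would stand at this place, since each would carry only one of those two changes.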